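A few compounds are considered here, and "the series" means these few. Any claim that something is new, unique, unknown or untested is made for them only; others in the source may bear on it.

Measured so far in a functional assay on MCF7 cells (Homo sapiens) for antiproliferative activity (a lower number here means a stronger inhibitor, a higher number a weaker inhibitor), for the series:
compound 1 `CC(=O)Nc1ccc(-c2nc3ccccc3s2)cc1C` gives > 10000 nM as a limit
compound 2 `CC(=O)Nc1ccc(-c2nc3ccccc3s2)cc1Cl` gives > 10 nM as a limit

Compound 1 has only a limit in this assay and no number. The other value in the series, that of compound 2, is also only a limit.

Compound 3 `CC(=O)N(C(C)=O)c1ccc(-c2nc3ccccc3s2)cc1C` is not yet measured. It differs from compound 1 by acetyl in place of hydrogen on an amide-type nitrogen, acetamido to diacetylamino, counted as acetyl in place of hydrogen on an amide-type nitrogen in full.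

Among the measured compounds shown here, the only measured step, chloro in place of methyl on an aromatic carbon, is a step that the two limits leave unreadable from compound 1 to compound 2 and so offers no size to carry over. For the measured compounds named here, it is also a different change, so no measured step bears directly on the acetyl change.

Compound 1, with > 10000 nM as its limit, remains the sole anchor, so no step beyond the scatter is expected in this assay and no direction is favoured. The expected change is a step that the limit leaves unreadable from compound 1 to compound 3 in this estimate. Compound 3 is estimated at 12000 nM with an expected range from 3000 nM to 50000 nM. Its eventual result may well be only a limit.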

Compound 3, half-maximal inhibitory concentration: > 10000 nM
Compound 3 gave a limit, no number; the forecaster's own chance of this, stated with the estimate: 75%; the middle value lies beyond the limit too.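

In this assay compound 3 gives > 10000 nM, which is a limit and not a number. Compound 1 also has only a limit, and the step between compound 1 and compound 3 cannot be read. The compounds shown leave open whether acetyl in place of hydrogen on the amide-type nitrogen changes the result in this assay at all.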